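The source may hold more compounds than are shown below. What is called first, only, known or untested is meant among the compounds shown, and "the series" means these compounds.

Compound 1 `CC(C)c1[nH]cnc1/C=c1\[nH]c(=O)/c(=C/c2cccc(Oc3ccc(F)cc3)c2)[nH]c1=O` gives the lowest of the two numbers shown in a functional assay on NCI-H460 cells (Homo sapiens) for cytotoxicity, read by MTT assay, with a stated time of 72 h (a higher number here means a weaker inhibitor, a lower number a stronger inhibitor), namely 8.8 nM. Compound 2 `Cc1[nH]cnc1/C=c1\[nH]c(=O)/c(=C/c2cccc(Oc3ccc(F)cc3)c2)[nH]c1=O`, which carries a smaller group on the same ring, gives 47.6 nM in this assay. Compound 3 `O=c1[nH]/c(=C\c2ncc[nH]2)c(=O)[nH]/c1=C\c1cccc(Oc2ccc(F)cc2)c1` reaches only a limit of this assay, > 1000 nM, so no number is known for it; this is the limit of > 1000 nM in this assay, at which 1 of the 3 values shown sits. The measured steps are a 5.4-fold higher number from compound 1 to compound 2 (0.73 log units; beyond the scatter) and the far larger an at least 110-fold higher number from compound 1 to compound 3 (2.05 log units; beyond the scatter), with an at least 21-fold higher number from compound 2 to compound 3 (1.32 log units; beyond the scatter) pointing the same way.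

Compound 4 `COCc1ccc(/C=c2\[nH]c(=O)/c(=C/c3cccc(Oc4ccc(F)cc4)c3)[nH]c2=O)o1` is the next step from compound 1: 5-(methoxymethyl)furan-2-yl in place of 5-isopropyl-1H-imidazol-4-yl on a double-bonded chain carbon bound to an aromatic carbon. All three measured steps bear on it. Trimming the substituent of that ring already cost a modest amount in a 5.4-fold higher number from compound 1 to compound 2 (0.73 log units; beyond the scatter), while exchanging the whole ring at this place for a different five-membered ring gave the large losses seen in an at least 110-fold higher number from compound 1 to compound 3 (2.05 log units; beyond the scatter) and an at least 21-fold higher number from compound 2 to compound 3 (1.32 log units; beyond the scatter). Compound 4 again swaps the ring itself, and for a ring with only one hetero atom, so a large rise in the number is expected, with a real chance that this assay again reports only a limit. For compound 4 the expected value is 400 nM, within 60 nM to 2500 nM, which would mean an expected step of a 45-fold higher number from compound 1 to compound 4 (1.66 log units; beyond the scatter).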

Compound 4, half-maximal inhibitory concentration: 14 nM
Estimate against measurement, compound 4: 29-fold (1.46 log units) above; the measured number lies below the stated range.
By their numbers in this assay, from the lowest: compounds 1 and 4 (each within the scatter of the next); then compound 2. At a limit, above all of these: compound 3.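

At this place, on a double-bonded chain carbon bound to an aromatic carbon, an imidazole ring turns out not to be needed for a low number in this assay: putting 5-(methoxymethyl)furan-2-yl in place of 5-isopropyl-1H-imidazol-4-yl, a ring with 1 hetero atom and 0 hydrogen-bond donors, gives a 1.6-fold higher number from compound 1 to compound 4 (0.20 log units; within the scatter). The same furan group also improves on 5-methyl-1H-imidazol-4-yl, with a 3.4-fold lower number from compound 2 to compound 4 (0.53 log units; beyond the scatter), and on 1H-imidazol-2-yl, with an at least 71-fold lower number from compound 3 to compound 4 (1.85 log units; beyond the scatter), so the large loss seen earlier belongs to that one ring and not to every exchange of the ring here. The value of compound 3, > 1000 nM, is a limit in this assay and not a number.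

Going by these compounds, what remains open is whether the furan ring or its methoxymethyl chain matters more, since the ring and the chain change together in compound 4. A 5-methylfuran-2-yl or 5-isopropylfuran-2-yl group would separate the two, and an aminomethyl or carboxylic acid group on the furan would test how much change the chain tolerates.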